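Exchanging the Aromatic Ring on the Amine Nitrogen

The source may report more compounds than this note shows. Statements on the series, on what has been measured and on what is new or still open speak of the compounds shown alone.

Compound 2 `Nc1scc(CN2CCN(c3ccc(C(F)(F)F)cc3)CC2)c1C(=O)c1ccc(Cl)cc1` gives 1 nM in an assay on CHO cells for displacement of a labelled ligand from adenosine receptor A1 (Homo sapiens) (a lower number here means tighter binding, a higher number weaker binding), level with compound 1 `Nc1scc(CN2CCN(c3ccc(F)cc3)CC2)c1C(=O)c1ccc(Cl)cc1`, which gives 1 nM. Among the measured compounds shown here, the one known step, no change at the digits printed from compound 1 to compound 2 (within the scatter), left the value unchanged. Compound 3 `Nc1scc(CN2CCN(c3ncccn3)CC2)c1C(=O)c1ccc(Cl)cc1` differs from compound 2 by pyrimidin-2-yl in place of 4-(trifluoromethyl)phenyl on an amine nitrogen in a ring. For the measured compounds named here, no measured step covers this exchange of one aromatic ring for another, so the flat step between the two measured compounds is only weak guidance. A small weakening, within or just beyond the scatter, is therefore expected in this assay: a 3.0-fold higher number from compound 2 to compound 3 (0.48 log units; beyond the scatter). Compound 3 is expected to give 3 nM, between 0.7 nM and 15 nM.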

Compound 3, dissociation constant: 1.1 nM
Compound 3: middle estimate off by 2.7-fold (0.44 log units), on the high side; measured number inside the range.
By their numbers in this assay, from the lowest: compounds 1, 2 and 3 (each within the scatter of the next).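

In this assay the pyrimidin-2-yl group on the amine nitrogen in a ring gives a 1.1-fold higher number from compound 2 to compound 3 (0.04 log units; within the scatter) and a 1.1-fold higher number from compound 1 to compound 3 (0.04 log units; within the scatter) and so keeps the number within the scatter. This position therefore takes an aromatic ring with 2 hetero atoms as well as one of carbon only, so the flat result now extends from a change of substituent to a change of the ring itself. The compounds shown leave open whether any aromatic ring is needed on this nitrogen, which a methyl or acetyl group there would test. No evidence is available on what lies behind these flat steps.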